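Swapping fluoro for iodo on the outer aromatic ring

The source may hold more compounds than are shown below. What is called first, only, known or untested is meant among the compounds shown, and "the series" means these compounds.

Of the compounds shown here, three sharing one core have been measured in an assay on cells for activation of probable G-protein coupled receptor 34 (Mus musculus), with a stated time of 1 h; on this read-out lower numbers stand for smaller maximal responses and higher numbers for larger maximal responses. Compound 1 `N[C@@H](COP(=O)(O)OCCCOC(=O)CCc1ccccc1OCc1cccc(Oc2cccc(Cl)c2)c1)C(=O)O` gives 0.53. Compound 2 `N[C@@H](COP(=O)(O)OCCCOC(=O)CCc1ccccc1OCc1cccc(Oc2ccc(Cl)cc2)c1)C(=O)O` gives 0.76, and compound 3 `N[C@@H](COP(=O)(O)OCCCOC(=O)CCc1ccccc1OCc1cccc(Oc2ccc(F)cc2)c1)C(=O)O` gives 0.66. Among these three numbers compound 3 stands second highest: the nearer of its two steps is a number 0.10 lower from compound 2 to compound 3 (within the scatter), which is within the scatter, while the move from compound 1 to compound 3 is a number 0.13 higher from compound 1 to compound 3 (beyond the scatter), beyond the scatter.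

Compound 4 `N[C@@H](COP(=O)(O)OCCCOC(=O)CCc1ccccc1OCc1cccc(Oc2ccc(I)cc2)c1)C(=O)O` differs from compound 3 in a single place: iodo in place of fluoro on an aromatic carbon. Going by the values given here, the only measured step that bears directly on this is the one between compound 2 and compound 3, the swap of one halogen for another on the same aromatic carbon, which came out as a number 0.10 lower from compound 2 to compound 3 (within the scatter) and so within the scatter. The larger steps, a number 0.23 higher from compound 1 to compound 2 (beyond the scatter) and a number 0.13 higher from compound 1 to compound 3 (beyond the scatter), concern moving the chloro from one position to another and do not speak to a halogen exchange at a fixed position.

On this basis the expected change in this assay from compound 3 to compound 4 is a number 0.060 higher from compound 3 to compound 4 (within the scatter), a step not clearly beyond the scatter in either direction. Compound 4 is therefore estimated at 0.72, with a range from 0.52 to 0.9.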

Compound 4, intrinsic activity: the largest response reached, as a fraction of the reference agonist's: 0.82
Compound 4: the middle estimate sits 0.10 below what was measured, and the stated range covers the measured number.
By their numbers in this assay, from the lowest: compound 1; then compounds 3, 2 and 4 (each within the scatter of the next, the first and the last beyond it).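

In this assay, exchanging one halogen for another on this aromatic carbon, para to a large group, can move the read-out beyond the scatter: going from 4-fluorophenyl to 4-iodophenyl gives a number 0.16 higher from compound 3 to compound 4 (beyond the scatter), whereas the earlier fluoro-for-chloro exchange at the same carbon stayed within it. Iodo and chloro at this carbon cannot be told apart, however, with a number 0.060 higher from compound 2 to compound 4 (within the scatter), so the compounds show a real difference between fluoro and iodo but none between chloro and iodo, and they do not support a clean ranking of all three halogens. The largest step seen so far in the series is a number 0.29 higher from compound 1 to compound 4 (beyond the scatter), and no independent measurement is available to explain any of these differences.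

From the compounds shown here alone, it remains open where a bromo group would fall at this carbon, and whether a methyl, a methoxy or a nitrile there would keep the read-out in the same range as the halogens. Also open, going by these compounds, is how an iodo group would behave at another carbon of the same ring, a question that compound 1 raises only for chloro.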